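Turning the Mirror: From Compound 2 to Compound 3

The source may report more compounds than this note shows. Statements on the series, on what has been measured and on what is new or still open speak of the compounds shown alone.

Compound 2 `COC(=O)[C@@H]1C[C@H]2CN[C@@H]1C2` stands highest of the two compounds measured in a functional assay on the whole organism (Superior cervical ganglion) with Rattus norvegicus as the target; on this read-out higher numbers stand for larger maximal responses and lower numbers for smaller maximal responses; in that assay compound 2 gives 90%. Compound 1 `COC(=O)C1CC2CNC1C2` has the same atoms and bonds but is drawn without any configuration, and in this assay compound 1 gives 57%. Among the measured compounds shown here, the only measured step, a number 33 percentage points higher from compound 1 to compound 2 (beyond the scatter), goes with the fact that one of compounds 1 and 2 is drawn with a defined configuration and the other without, at the place where they differ: a drawing without configuration may stand for a mixture of both mirror forms, and the single drawn form reaches a larger maximal response than the mixture. Compound 3 `COC(=O)[C@H]1C[C@@H]2CN[C@H]1C2` differs from compound 2 as follows: the two compounds have the same atoms and bonds and differ only in configuration as drawn: 3 of 3 stereo elements differ (all stereocentres are inverted: mirror images); a stereocentre at a saturated ring carbon is drawn R in compound 2 and S in compound 3; a stereocentre at a saturated ring carbon is drawn R in compound 2 and S in compound 3; a stereocentre at a saturated ring carbon is drawn R in compound 2 and S in compound 3. If compound 1 represents the mixture and compound 2 its better half, the mirror image would carry the weaker share, so in this assay a downward step beyond the scatter, a number 60 percentage points lower from compound 2 to compound 3 (beyond the scatter), is expected. Compound 3 is therefore estimated at 30%, within a range from 10% to 60%.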

Compound 3, largest response reached (reported as efficacy), in percent of the reference or control that the assay uses: 47%
The estimate for compound 3 lay 17 percentage points below the measured number; low and high end bracket the measured number.
By their numbers in this assay, from the lowest: compounds 3 and 1 (each within the scatter of the next); then compound 2.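

In this assay, the maximal response follows the handedness of the shared core, with a number 43 percentage points lower from compound 2 to compound 3 (beyond the scatter), and the two compounds differ in one respect only: the fact that compounds 2 and 3 differ only in the configuration as drawn. The form drawn S cannot be told apart from the drawing without configuration, with a number 10 percentage points lower from compound 1 to compound 3 (within the scatter), and these two also differ only in what is drawn: the fact that one of compounds 1 and 3 is drawn with a defined configuration and the other without, at the place where they differ. Of the three, compound 2 alone stands clear of the other two by more than the scatter, so the large maximal response belongs to one mirror form and not to the atoms and bonds alone.

The drawing of compound 1 does not tell whether it is a mixture of both mirror forms, or in what proportion. Also open, from the compounds shown here alone, is whether the gap between the mirror forms would persist with a carboxylic acid or an amide in place of the ester.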